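From phenyl to 2-chloro-4-fluorophenyl in a growth read-out

A few compounds are considered here, and "the series" means these few. Any claim that something is new, unique, unknown or untested is made for them only; others in the source may bear on it.

Measured in a functional assay on PC-3 cells (Homo sapiens) (on this read-out lower numbers stand for stronger inhibition of growth and higher numbers for weaker inhibition of growth), so far:
- compound 1 `O=S(=O)(/C=C/c1ccccc1)Cc1ccc(Nc2ncnc3ccccc23)cc1` gives > 100000 nM (a limit)
- compound 2 `O=S(=O)(/C=C/c1ccc(Br)cc1)Cc1ccc(Nc2ncnc3ccccc23)cc1` gives 42000 nM
- compound 3 `O=S(=O)(/C=C/c1ccc(Cl)cc1Cl)Cc1ccc(Nc2ncnc3ccccc23)cc1` gives 19000 nM

Compound 1 stands at the limit of > 100000 nM in this assay, at which 1 of the 3 values shown sits, and that entry is a limit, not a number.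

Compound 4 `O=S(=O)(/C=C/c1ccc(F)cc1Cl)Cc1ccc(Nc2ncnc3ccccc23)cc1` has not yet been measured. It differs from compound 1 in one place, where 2-chloro-4-fluorophenyl replaces phenyl on a double-bonded chain carbon bound to a double-bonded chain carbon: 2-chloro-4-fluorophenyl in place of phenyl on a double-bonded chain carbon bound to a double-bonded chain carbon.

Two measured steps start from the same compound. One is an at least 2.3-fold lower number from compound 1 to compound 2 (0.37 log units; beyond the scatter) for bromo in place of hydrogen on an aromatic carbon. The other is an at least 5.2-fold lower number from compound 1 to compound 3 (0.72 log units; beyond the scatter) for 2,4-dichlorophenyl in place of phenyl. Within the data shown here, the two substituted compounds also differ from each other by a 2.2-fold lower number from compound 2 to compound 3 (0.34 log units; beyond the scatter) and no measured compound goes against the drop from the limit.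

Compound 3 at 19000 nM is the closest measured match, since its ring also carries chlorine and a second halogen. A lower number is therefore expected in this assay for the new compound, of at least modest size. The estimated size is an at least 4.1-fold lower number from compound 1 to compound 4 (0.61 log units; beyond the scatter) in that direction. For compound 4 the expected value is 24000 nM with an estimated range from 9000 nM to 60000 nM in this read-out.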

Compound 4, concentration for 50% growth inhibition: 100000 nM
For compound 4 the middle estimate is 4.2-fold (0.62 log units) below the measured one, and the stated range ends below it.
By their numbers in this assay, from the lowest: compound 3; then compound 2; then compound 4.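

Read in this assay, this result shows that a halogen on the ring is not enough in itself, and that which halogen it is matters: a 5.3-fold higher number from compound 3 to compound 4 (0.72 log units; beyond the scatter) for the single exchange of fluoro in place of chloro on an aromatic carbon. The earlier compounds shown here could suggest that two halogens on the ring give a lower number than one, but compound 4 goes against that reading, with a 2.4-fold higher number from compound 2 to compound 4 (0.38 log units; beyond the scatter) when 2-chloro-4-fluorophenyl replaces 4-bromophenyl. The data give a number no higher from compound 1 to compound 4 (the limit leaves the size open) for 2-chloro-4-fluorophenyl in place of phenyl. The size of this change cannot be read, as the entry for compound 1 is a limit and not a number: the limit of > 100000 nM in this assay, at which 1 of the 4 values shown sits.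

The compounds shown leave open whether a methoxy group or a nitrile on this ring would follow chloro or fluoro, and so whether a halogen is needed at all. They also leave open whether a ring carrying only a single chloro or a single fluoro would give a number closer to that of compound 3 or to that of compound 4.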